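The source may hold more compounds than are shown below. What is called first, only, known or untested is meant among the compounds shown, and "the series" means these compounds.

Working notes on the series. Compound 1 `N#CCn1c2ccc([N+](=O)[O-])cc2c(=O)n1Cc1ccccc1` is read in an ADME assay on L929 cells (Mus musculus) for cytotoxicity, read by resazurin assay, with a stated time of 48 h (on this read-out higher numbers stand for lower toxicity in this test and lower numbers for higher toxicity in this test), where compound 1 gives > 256000 nM, which is a limit of the assay and not a number. Compound 3 `O=c1c2cc([N+](=O)[O-])ccc2n(CCO)n1Cc1ccccc1` gives > 256000 nM in this assay, also a limit. For the measured compounds named here, compound 2 `CCOC(=O)CCCn1c2ccc([N+](=O)[O-])cc2c(=O)n1Cc1ccccc1` gives 78100 nM in this assay, the only plain number of the three. The step of an at least 3.2-fold lower number from compound 1 to compound 2 (0.51 log units; beyond the scatter) and the step of an at least 3.2-fold higher number from compound 2 to compound 3 (0.51 log units; beyond the scatter) show that a longer ester-bearing chain lowers the number, while the step that the two limits leave unreadable from compound 1 to compound 3 stays unreadable since (the limit of > 256000 nM in this assay, at which 2 of the 3 values shown sit). Compound 4 `COCCn1c2ccc([N+](=O)[O-])cc2c(=O)n1Cc1ccccc1` differs from compound 1 by methoxymethyl in place of cyano on a saturated chain carbon bound to an aromatic nitrogen. The change is small and neutral, closer in kind to compound 3 than to compound 2, so for compound 4 the step of an at least 1.2-fold lower number from compound 1 to compound 4 (0.10 log units; that floor lies within the scatter) is expected to be none beyond the scatter, with a fair chance of another limit. Compound 4 is estimated at 200000 nM, between 70000 nM and 400000 nM.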

Compound 4, concentration lethal to 50% of the cells: > 256000 nM
Compound 4: only a limit was reported; the forecaster's own chance of this, stated with the estimate: 55%; middle value at least 1.2-fold (0.10 log units) from the limit.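

In this assay compound 4 gives > 256000 nM, a limit of the assay and not a number. Methoxy in place of (ethoxycarbonyl)methyl gives an at least 3.2-fold higher number from compound 2 to compound 4 (0.51 log units; beyond the scatter), so the free hydroxy of compound 3 is not needed for a step of this kind away from the ester of compound 2. The steps from compound 1 and compound 3 to compound 4 cannot be read, because these compounds share one limit: the limit of > 256000 nM in this assay, at which 3 of the 4 values shown sit.

From the compounds shown here alone, whether the lower number of compound 2 goes with the ester or with the chain length stays open. A plain longer alkyl chain or the corresponding carboxylic acid would separate the two.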